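This account rests on a few compounds, and the source may have more. Where it says the series, first, only, none or still open, it means among the compounds named here.

Measured compounds:
compound 1 `CC(C)C(=O)N1CCC[C@H]1C(=O)N1CCC(NS(=O)(=O)c2cc(S(=O)(=O)c3ccccc3)ccc2C(F)(F)F)CC1` in a functional assay on U2OS cells for antagonist activity at proto-oncogene Wnt-3 (Homo sapiens), read by a luciferase reporter, with a stated time of 18 h (on this read-out higher numbers stand for an effect only at larger amounts of compound and lower numbers for an effect already at smaller amounts), gives 90 nM
compound 2 `CCNC(=O)N1CCC[C@H]1C(=O)N1CCC(NS(=O)(=O)c2cc(S(=O)(=O)c3ccccc3)ccc2C(F)(F)F)CC1` in this assay gives 90 nM
compound 3 `CN1CCC[C@H]1C(=O)N1CCC(NS(=O)(=O)c2cc(S(=O)(=O)c3ccccc3)ccc2C(F)(F)F)CC1` in this assay gives 230 nM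

Compound 3 has the highest number of the three. The two steps reaching it, a 2.6-fold higher number from compound 1 to compound 3 (0.41 log units; beyond the scatter) and a 2.6-fold higher number from compound 2 to compound 3 (0.41 log units; beyond the scatter), are both modest and both beyond the scatter, while no change at the digits printed from compound 1 to compound 2 (within the scatter) stays within it. Compound 4 `CC(C)(C)CCN1CCC[C@H]1C(=O)N1CCC(NS(=O)(=O)c2cc(S(=O)(=O)c3ccccc3)ccc2C(F)(F)F)CC1` differs from compound 3 by neopentyl in place of hydrogen on a saturated chain carbon bound to an amine nitrogen in a ring. Within the data shown here, no measured step covers this change; the steps to compound 3 only show that a larger group on that ring nitrogen went with a lower number. Compound 4 is therefore expected to show a small decrease in this assay, a 1.5-fold lower number from compound 3 to compound 4 (0.19 log units; within the scatter), or none beyond the scatter. Compound 4 is estimated at 150 nM, between 60 nM and 400 nM.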

Compound 4, half-maximal effective concentration: 450 nM
Beside the measured number, compound 4's estimate is 3.0-fold (0.48 log units) below it, and the stated range ends below it.
By their numbers in this assay, from the lowest: compounds 1 and 2 (each within the scatter of the next); then compounds 3 and 4 (each within the scatter of the next).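

In this assay, 3,3-dimethylbutyl in place of methyl on the amine nitrogen in the ring gives a 2.0-fold higher number from compound 3 to compound 4 (0.29 log units; within the scatter) and so does not separate these two compounds. The longer chain also stays apart from the isopropylcarbonyl and ethylcarbamoyl groups on that nitrogen, with a 5.0-fold higher number from compound 2 to compound 4 (0.70 log units; beyond the scatter) and a 5.0-fold higher number from compound 1 to compound 4 (0.70 log units; beyond the scatter) as the steps from those compounds. Nothing measured here accounts for this result. The compounds shown leave open how an acetyl group, a methanesulfonyl group or only hydrogen on that nitrogen would read out here.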